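Notes on compounds 1 to 3

The source may report more compounds than this note shows. Statements on the series, on what has been measured and on what is new or still open speak of the compounds shown alone.

Measured so far:
compound 1 `CC(C)(C)c1ccc(CNCCCNS(=O)(=O)c2cc(C(F)(F)F)cc(C(F)(F)F)c2)cc1` — 2300 nM
compound 2 `COc1ccccc1CNCCCNS(=O)(=O)c1cc(C(F)(F)F)cc(C(F)(F)F)c1` — 3100 nM

In a functional assay on MIA PaCa-2 cells (Homo sapiens) for inhibition, read by MTT assay, with a stated time of 72 h (a higher number here means a weaker inhibitor of growth, a lower number a stronger inhibitor of growth), compound 1 gives 2300 nM and compound 2 gives 3100 nM. Compound 2 holds the higher of the two numbers, but the step of a 1.3-fold higher number from compound 1 to compound 2 (0.13 log units; within the scatter) is within the scatter, so the two compounds cannot be ordered on these data.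

Compound 3 `COc1ccc(CNCCCNS(=O)(=O)c2cc(C(F)(F)F)cc(C(F)(F)F)c2)cc1` differs from compound 2 in one place: 4-methoxyphenyl in place of 2-methoxyphenyl on a saturated chain carbon bound to an amine nitrogen. Among the compounds with values here, the only measured step, from compound 1 to compound 2, exchanged one aryl group for another on the same saturated chain carbon and produced no change beyond the scatter. Within the data shown here, no measured pair compares a 2-methoxyphenyl with a 4-methoxyphenyl, so nothing bears directly on this change. The expectation for compound 3 is therefore no step beyond the scatter, with a 1.0-fold lower number from compound 2 to compound 3 (0.01 log units; within the scatter) as the estimated step. Compound 3 is estimated at 3000 nM, within a range of 1200 nM to 7500 nM.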

Compound 3, concentration for 50% growth inhibition: 2500 nM
For compound 3 the middle estimate is 1.2-fold (0.08 log units) above the measured one; measured number inside the range.
By their numbers in this assay, from the lowest: compounds 1, 3 and 2 (each within the scatter of the next).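

In this assay, within the data shown here, exchanging 2-methoxyphenyl for 4-methoxyphenyl on a saturated chain carbon bound to an amine nitrogen gives a 1.2-fold lower number from compound 2 to compound 3 (0.09 log units; within the scatter), the first direct comparison of two placements of the methoxy group on this aryl ring, and it shows no change beyond the scatter. Methoxy in place of tert-butyl on an aromatic carbon gives a 1.1-fold higher number from compound 1 to compound 3 (0.04 log units; within the scatter), so this exchange at a single ring position also shows no change beyond the scatter. No measured data on these compounds bear on why these steps are so small.

The compounds shown leave open whether a carboxylic acid or an amine on the aryl ring would move the number beyond the scatter. They also leave open what a longer chain in the shared core would do.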